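The source may report more compounds than this note shows. Statements on the series, on what has been measured and on what is new or still open speak of the compounds shown alone.

Compound 1 `Cc1cccc(C)c1Oc1cc(Nc2ccc(C#N)cc2)[nH]c(=O)c1Br` gives 63000 nM in an ADME assay on MT4 cells (Homo sapiens) for cytotoxicity, read by MTT assay, with a stated time of 5 days; a lower number here means that less compound is tolerated, a higher number that more compound is tolerated. Compound 2 `COc1cc(Oc2c(C)cc(C)cc2C)cc(Nc2ccc(C#N)cc2)n1` gives 29000 nM in this assay. Compound 3 `Cc1cc(C)c(Oc2cc(Nc3ccc(C#N)cc3)[nH]c(=O)c2Br)c(C)c1` gives only a limit, > 294000 nM, in this assay.

Compound 2 shows a lower number than compound 1; between compounds 2 and 3 the difference of the two cores is not broken down here. From compound 3 to compound 1 the change is hydrogen in place of methyl on an aromatic carbon, and in this assay it made an at least 4.6-fold lower number from compound 3 to compound 1 (0.66 log units; beyond the scatter), a step that rests on a limit, (the limit of > 294000 nM in this assay, at which 1 of the 3 values shown sits). Compound 4 `COc1cc(Oc2c(C)cccc2C)cc(Nc2ccc(C#N)cc2)n1` carries the same change against compound 2, (hydrogen in place of methyl on an aromatic carbon), at the same place. By that step, compound 4 is expected to show a 2.9-fold lower number from compound 2 to compound 4 (0.46 log units; beyond the scatter) in this assay. Compound 4 is therefore estimated at 10000 nM, within 4000 nM to 30000 nM.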

Compound 4, half-maximal cytotoxic concentration: 8500 nM
Compound 4: the middle estimate sits 1.2-fold (0.07 log units) above what was measured; the range from low to high includes it.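

In this assay, the change from 2,4,6-trimethylphenyl to 2,6-dimethylphenyl gave a 3.4-fold lower number from compound 2 to compound 4 (0.53 log units; beyond the scatter), so the direction seen on the core of compound 1 also appears on the core of compound 2. This shows that the change carried over in direction across these two pairs, and no pair shown goes against it. It does not show that the change has the same size on both cores, since one of the two steps rests on a limit: the same change on two cores in this assay, an at least 4.6-fold lower number (0.66 log units; beyond the scatter) from compound 3 to compound 1 and a 3.4-fold lower number (0.53 log units; beyond the scatter) from compound 2 to compound 4; the limit leaves it open whether they differ

Going by these compounds, whether the change acts the same way on any further core remains open. Also open, on these data alone, is how this place would respond to an ethyl group, a chlorine atom or an amine in place of the methyl group.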